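This account rests on a few compounds, and the source may have more. Where it says the series, first, only, none or still open, it means among the compounds named here.

Two measured compounds frame the question. Going by the values given here, compound 1 `CCN(CCC(Oc1ccc(C(F)(F)F)cc1)c1ccccc1)CC(=O)O` gives 5010 nM in an assay on CHO cells for inhibition of sodium- and chloride-dependent glycine transporter 1 (Homo sapiens) (on this read-out higher numbers stand for weaker inhibition and lower numbers for stronger inhibition), and compound 2 `CN(CCC(=O)O)CCC(Oc1ccc(C(F)(F)F)cc1)c1ccccc1` gives 31600 nM in this assay , the highest of the two numbers, with compound 1 as its only neighbour. Among the compounds with values here, the step of a 6.3-fold higher number from compound 1 to compound 2 (0.80 log units; beyond the scatter) is the single measured change, and it altered both groups on the amine at once, so it bears only in part on what follows. Compound 3 `CN(CCCC(=O)O)CCC(Oc1ccc(C(F)(F)F)cc1)c1ccccc1` differs from compound 2 by carboxymethyl in place of carboxy on a saturated chain carbon, two bonds along the chain from an amine nitrogen. Lengthening the acid-bearing chain was accompanied by weaker inhibition in the one step available, although that step was not a pure chain extension. Compound 3 is therefore expected to show a step of about a 1.4-fold higher number from compound 2 to compound 3 (0.15 log units; within the scatter), with wide uncertainty, toward a higher number. The estimate for compound 3 is 45000 nM, in a range from 12000 nM to 150000 nM.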

Compound 3, half-maximal inhibitory concentration: 100000 nM
Estimate against measurement, compound 3: 2.2-fold (0.35 log units) below, within the range that was stated.
By their numbers in this assay, from the lowest: compound 1; then compound 2; then compound 3.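

Going by these compounds alone, compound 3 gives the first reading in which only the acid-bearing chain changes while the methyl on the amine stays fixed: 3-carboxypropyl in place of 2-carboxyethyl brings a 3.2-fold higher number from compound 2 to compound 3 (0.50 log units; beyond the scatter) in this assay. Inhibition therefore weakens with this extension alone, a change that the earlier step could not isolate, since it altered both groups on the amine. The wider step, a 20-fold higher number from compound 1 to compound 3 (1.30 log units; beyond the scatter), also spans both groups, so it cannot be divided between them, and no supporting data bear on why the number rises.

The compounds shown leave open how much of that wider step belongs to the ethyl on the amine and how much to the length of the acid-bearing chain. They also leave open whether a 4-carboxybutyl chain would extend the trend, or how a primary amide in place of the carboxylic acid would read.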